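Indole thioether series: ethoxy for fluoro on the bicyclic core

A few compounds are considered here, and "the series" means these few. Any claim that something is new, unique, unknown or untested is made for them only; others in the source may bear on it.

Measured compounds:
compound 1 `Cc1ccccc1Sc1c[nH]c2ccc(Cl)cc12` — 21000 nM
compound 2 `COc1ccccc1Sc1c[nH]c2ccc(F)cc12` — 32000 nM

In an assay on isolated protein for inhibition of Indoleamine 2,3-dioxygenase 1 (Homo sapiens), read by HPLC, with a stated time of 60 min, in the presence of a further agent that is not named here (on this read-out higher numbers stand for weaker inhibition and lower numbers for stronger inhibition), compound 2 gives 32000 nM. Compound 1 gives 21000 nM in the same assay, and the two numbers lie within the usual scatter of each other; compound 2 cannot be set apart from compound 1 on these data. Both compounds share the core of compound 2, differing in the group on the pendant aryl ring and in the halogen on the fused ring.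

Compound 3 `CCOc1ccc2[nH]cc(Sc3ccccc3OC)c2c1` has not yet been measured in this assay. It differs from compound 2 by ethoxy in place of fluoro on an aromatic carbon of the fused six-membered ring, meta and para to the fused ring.

Going by the values given here, no measured step of this kind exists, so the direction cannot be read from the data. The expectation for compound 3 is a step of a 1.3-fold lower number from compound 2 to compound 3 (0.11 log units; within the scatter) from compound 2 of small size, not clearly beyond the scatter, with wide uncertainty. Compound 3 is estimated at 25000 nM, in a range from 8000 nM to 80000 nM.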

Compound 3, half-maximal inhibitory concentration: > 200000 nM
Compound 3 ended at the assay's limit (the forecaster's own chance of this, stated with the estimate: 20%); middle value at least 8.0-fold (0.90 log units) from the limit.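

In this assay compound 3 gives > 200000 nM, which is a limit of the assay and not a number: the limit of > 200000 nM in this assay, at which 1 of the 3 values shown sits.

Ethoxy in place of fluoro on this aromatic carbon gives an at least 6.2-fold higher number from compound 2 to compound 3 (0.79 log units; beyond the scatter), so the true size of the step remains unknown. Compound 1 and compound 2 differ in two places and could say nothing about this position alone, whereas this single change shows that inhibition in this assay depends on the group carried at this carbon.

The compounds shown do not tell whether the loss goes with the ring-bound oxygen or with the ethyl part of the ethoxy group. An amine or a longer chain such as propoxy on the same carbon would remain to be compared with fluoro, and the effect of either group here is open.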